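Removing the 2-aminoethoxy chain from compound 2

This account rests on a few compounds, and the source may have more. Where it says the series, first, only, none or still open, it means among the compounds named here.

Going by the values given here, compound 2 `NCCOc1cc(-c2cccnc2)ccc1C(N)=O` stands lowest of the two numbers measured so far: in an assay on cells for inhibition of MAP kinase-interacting serine/threonine-protein kinase 1 (Homo sapiens), read by mobility shift assay, with stated times of 10 min and 60 min, in the presence of a further agent that is not named here (on this read-out lower numbers stand for stronger inhibition and higher numbers for weaker inhibition), compound 2 gives 820 nM, while compound 1 `NC(=O)c1ccc(-c2cncc(Cl)c2)cc1` gives 14200 nM in this assay, a gap beyond the scatter. Compound 3 `NC(=O)c1ccc(-c2cccnc2)cc1` differs from compound 2 by one change only: hydrogen in place of 2-aminoethoxy on an aromatic carbon. Among the compounds with values here, no step between measured compounds covers this change, so the outcome rests on little; still, it is expected that a 6.1-fold higher number from compound 2 to compound 3 (0.79 log units; beyond the scatter) goes toward a higher number, by a step beyond the scatter. Accordingly compound 3 is estimated at 5000 nM in this assay, within a range from 1500 nM to 20000 nM.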

Compound 3, half-maximal inhibitory concentration: 8800 nM
Compound 3: the middle estimate sits 1.8-fold (0.25 log units) below what was measured; the range from low to high includes it.
By their numbers in this assay, from the lowest: compound 2; then compounds 3 and 1 (each within the scatter of the next).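

In this assay hydrogen in place of 2-aminoethoxy, on the aromatic carbon ortho to a carbamoyl group, gives an 11-fold higher number from compound 2 to compound 3 (1.03 log units; beyond the scatter) and so ties the lower number to this chain alone, which the gap to compound 1 could not do, since compound 1 differs in a further place. Hydrogen in place of chloro on an aromatic carbon gives a 1.6-fold lower number from compound 1 to compound 3 (0.21 log units; within the scatter) and leaves the two within the scatter of each other. Going by these compounds, whether the chain's amine is needed, or whether methoxy, a carboxylic acid or a longer chain at this position would give a similar number, stays open. Nothing at hand explains the size of the step.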